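The source may report more compounds than this note shows. Statements on the series, on what has been measured and on what is new or still open speak of the compounds shown alone.

Three compounds that share one core have been tested in a functional assay on HGC-27 cells (Homo sapiens) for inhibition, read by MTT assay, with a stated time of 72 h; a lower number here means a stronger inhibitor, a higher number a weaker inhibitor:

Compound 1, `Cc1cc(N2CC[C@@H](C)[C@@H](N(C)c3ncnc4[nH]ccc34)C2)n2ncnc2n1`, gives 11300 nM.
Compound 2, `Cc1cc(N2CC[C@@H](C)[C@@H](N(C)c3ncnc4[nH]ccc34)C2)n2nc(SCC3CC3)nc2n1`, gives 21400 nM.
Compound 3, `Cc1cc(N2CC[C@@H](C)[C@@H](N(C)c3ncnc4[nH]ccc34)C2)n2nc(SCc3ccc(Br)cc3)nc2n1`, gives 19500 nM.

Compound 3 holds the second highest of the three numbers. Its nearest neighbour is compound 2, with a 1.1-fold lower number from compound 2 to compound 3 (0.04 log units; within the scatter), and its furthest is compound 1, with a 1.7-fold higher number from compound 1 to compound 3 (0.24 log units; within the scatter); both of these steps lie within the scatter, as does a 1.9-fold higher number from compound 1 to compound 2 (0.28 log units; within the scatter). Across the three measured compounds, then, the group attached through sulfur to the aromatic carbon has made no difference that rises above the usual spread of this assay.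

Compound 4, `Cc1ccc(CSc2nc3nc(C)cc(N4CC[C@@H](C)[C@@H](N(C)c5ncnc6[nH]ccc56)C4)n3n2)cc1`, differs from compound 3 in one place: methyl in place of bromo on an aromatic carbon. Among the measured compounds shown here, no measured step changes this part of the structure, so the change must be judged only on what the three compounds together show, which is that variation in the (4-bromobenzyl)sulfanyl region has left this assay essentially flat. Compound 4 is therefore expected to land close to compound 3, with a step of a 1.1-fold lower number from compound 3 to compound 4 (0.03 log units; within the scatter) that stays within the scatter. The estimate for compound 4 is 18000 nM, with a range from 8000 nM to 40000 nM.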

Compound 4, half-maximal inhibitory concentration: 15200 nM
The estimate for compound 4 lay 1.2-fold (0.07 log units) above the measured number, and the stated range covers the measured number.
By their numbers in this assay, from the lowest: compounds 1, 4, 3 and 2 (each within the scatter of the next).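

In this assay, the exchange of bromo for methyl on an aromatic carbon para to a large group gives a 1.3-fold lower number from compound 3 to compound 4 (0.11 log units; within the scatter), so the one step shown at this place on the benzyl ring does not rise above the usual spread. The new group also stays within the scatter against the other two substituents, with a 1.4-fold lower number from compound 2 to compound 4 (0.15 log units; within the scatter) against the (cyclopropylmethyl)sulfanyl compound and a 1.3-fold higher number from compound 1 to compound 4 (0.13 log units; within the scatter) against the compound carrying hydrogen, which extends the flat picture to all four compounds, with none of them going against it. Nothing at hand bears on why this change leaves the number where it is.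

What remains open is whether an amine or a carboxylic acid in place of methyl on the aromatic ring would produce a step beyond the scatter, since bromo and methyl are the only two groups shown at this place. From the compounds shown here alone, it is equally open whether a longer chain in place of the benzyl group, or an oxygen in place of the sulfur, would separate from these four compounds.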